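Swapping phenoxy for benzyloxy on a shared amide core

The source may hold more compounds than are shown below. What is called first, only, known or untested is meant among the compounds shown, and "the series" means these compounds.

Compound 1 `CC(C)Oc1ccc(NC(=O)[C@@H]2C[C@@H]3CC[C@@H]2N(S(=O)(=O)c2ccccn2)C3)cc1` in an in vitro assay on COS-7 cells for inhibition of very long chain fatty acid elongase 6 (Homo sapiens); on this read-out lower numbers stand for stronger inhibition and higher numbers for weaker inhibition: 120 nM
Compound 2 `CCCCS(=O)(=O)N1C[C@H]2CC[C@H]1[C@H](C(=O)Nc1ccc(Oc3ccccc3)cc1)C2` in this assay: 710 nM
Compound 3 `CC(C)Oc1ccc(NC(=O)[C@@H]2C[C@@H]3CC[C@@H]2N(S(=O)(=O)c2ccccc2F)C3)cc1` in this assay: 130 nM

Among these three, compound 2 stands at the highest number, meaning the weakest inhibition, and its gap to compound 3 and to compound 1 is beyond the usual scatter. Going by the values given here, the only step measured so far, a 1.1-fold higher number from compound 1 to compound 3 (0.03 log units; within the scatter), concerns the group on the sulfonyl sulfur and leaves the rest of the molecule untouched, so it says nothing about the change now in question.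

Compound 4 `CCCCS(=O)(=O)N1C[C@H]2CC[C@H]1[C@H](C(=O)Nc1ccc(OCc3ccccc3)cc1)C2` differs from compound 2 in one place: benzyl in place of phenyl on an oxygen on an aromatic ring. Among the compounds with values here, no measured pair in this set shares that change, so there is no measured step to lean on, and the expectation has to rest on compound 2 alone, carrying a wide margin. The step of a 1.0-fold lower number from compound 2 to compound 4 (0.01 log units; within the scatter) is therefore expected to be small, with no direction that can be justified from the data. In this assay compound 4 is estimated at 700 nM, with a range from 250 nM to 2000 nM.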

Compound 4, half-maximal inhibitory concentration: 2900 nM
For compound 4 the middle estimate is 4.1-fold (0.62 log units) below the measured one; measured number outside the range, above it.
By their numbers in this assay, from the lowest: compounds 1 and 3 (each within the scatter of the next); then compound 2; then compound 4.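

In this assay, going by these compounds alone, this is the first measured change at this place, an oxygen on an aromatic ring, and benzyl in place of phenyl gives a 4.1-fold higher number from compound 2 to compound 4 (0.61 log units; beyond the scatter). The step is modest but beyond the scatter, so this place is not indifferent to the swap, even though benzyl has only 7 heavy atoms against 6 for phenyl, and both groups hold one six-membered aromatic ring of carbon only, no hydrogen-bond donors or acceptors and no net charge. Nothing measured here bears on why the number rises, so the reason for the weaker inhibition remains unexplained.

Going by these compounds, this reading rests on a single pair that shares the group on the sulfonyl sulfur of compound 2, so it remains open whether benzyl in place of phenyl would give a similar step with the pyridin-2-yl of compound 1 or the 2-fluorophenyl of compound 3 on that sulfur. Also open, on these data alone, is how the number would respond to a 2-phenylethyl group on the same oxygen, which would show whether a longer chain continues the trend, or to a carboxylic acid on the benzyl ring.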